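The source may report more compounds than this note shows. Statements on the series, on what has been measured and on what is new or still open speak of the compounds shown alone.

Measured compounds in this series:

compound 1 `CN(CC1=CC[C@H]2C[C@@H]1C2(C)C)Cc1ccc(F)cc1`, 6310 nM
compound 2 `CC(=O)c1cccc(-c2ccc(CN(C)CC3=CC[C@H]4C[C@@H]3C4(C)C)cc2)c1`, > 316 nM

In an assay on HEK293 cells for displacement of a labelled ligand from C-X-C chemokine receptor type 3 (Homo sapiens) (on this read-out lower numbers stand for stronger inhibition and higher numbers for weaker inhibition), compound 1 gives 6310 nM. For compound 2 this assay reports only a limit, > 316 nM, and no number. Within the data shown here, the single measured step, a step that the limit leaves unreadable from compound 1 to compound 2, is therefore of unreadable size because of the limit of > 316 nM in this assay, at which 1 of the 2 values shown sits, and it gives no direction to build on.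

Compound 3 `Cc1cccc(-c2ccc(CN(C)CC3=CC[C@H]4C[C@@H]3C4(C)C)cc2)c1` is not yet measured in this assay. It differs from compound 2 by one change, (methyl in place of acetyl on an aromatic carbon), that is, methyl in place of acetyl on an aromatic carbon, meta to a large group. No measured step bears directly on this change; the only step shown, from compound 1 to compound 2, concerns a different position and is itself unreadable. Compound 2 stands only at a limit, so where compound 3 will stand cannot be read from the numbers shown, and a limit again is the likeliest outcome. The step from compound 2 to compound 3 is expected to be a step that the limit leaves unreadable from compound 2 to compound 3. Compound 3 is therefore estimated at 3000 nM in this assay, with a wide range from 400 nM to 20000 nM.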

Compound 3, inhibition constant: > 316 nM
Compound 3: no number, only a limit; the forecaster's own chance of this, stated with the estimate: 60%; the middle value lies beyond the limit too.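

Compound 3 gives only a limit in this assay, > 316 nM, and no number. No new step can be read among compound 1, compound 2 and compound 3, because of this: the limit of > 316 nM in this assay, at which 2 of the 3 values shown sit.

The compounds shown leave open how 3-acetylphenyl, 3-methylphenyl and fluoro compare on the shared core.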